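Replacing the thiazolyl sulfanyl group of compound 3

A few compounds are considered here, and "the series" means these few. Any claim that something is new, unique, unknown or untested is made for them only; others in the source may bear on it.

- compound 1 `CC(C)=CCn1nc(-c2cccnc2)c2ccccc2c1=O` at 1380 nM 
- compound 2 `CC(=O)Cn1nc(-c2cccnc2)c2ccccc2c1=O` at 40700 nM 
- compound 3 `O=c1c2ccccc2c(-c2cccnc2)nn1CCSc1nccs1` at 10500 nM 

All three values come from a functional assay (trachea) with Cavia porcellus as the target (on this read-out higher numbers stand for weaker inhibition and lower numbers for stronger inhibition), and compound 3 sits in the middle of them, with 10500 nM as the second highest number.

The next change turns compound 3 into compound 4 `CC(C)NC(=O)CCCn1nc(-c2cccnc2)c2ccccc2c1=O` by putting (isopropylcarbamoyl)methyl in place of (1,3-thiazol-2-yl)sulfanyl on a saturated chain carbon, two bonds along the chain from an aromatic nitrogen.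

Three measured steps at this same chain bear on the change. They are a 29-fold higher number from compound 1 to compound 2 (1.47 log units; beyond the scatter) which is large, a 7.6-fold higher number from compound 1 to compound 3 (0.88 log units; beyond the scatter) which is modest, and a 3.9-fold lower number from compound 2 to compound 3 (0.59 log units; beyond the scatter) which is also modest. The chain can therefore move the number considerably, but none of these steps introduces an amide. No direction is firm, and no shift beyond the scatter is expected in this assay for this change. The estimated step is a 1.3-fold lower number from compound 3 to compound 4 (0.12 log units; within the scatter) and it carries wide uncertainty.

Compound 4 is estimated at 8000 nM within an expected range of 2000 nM to 30000 nM in this read-out.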

Compound 4, half-maximal inhibitory concentration: 64600 nM
Compound 4: middle estimate off by 8.1-fold (0.91 log units), on the low side; the measured number lies above the stated range.
By their numbers in this assay, from the lowest: compound 1; then compound 3; then compounds 2 and 4 (each within the scatter of the next).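

In this assay, for the compounds shown here, this is the first reading of an amide on this chain, and putting (isopropylcarbamoyl)methyl in place of (1,3-thiazol-2-yl)sulfanyl weakens inhibition (a 6.2-fold higher number from compound 3 to compound 4 (0.79 log units; beyond the scatter)). The longer amide chain reads level with the much shorter acetyl chain (a 1.6-fold higher number from compound 2 to compound 4 (0.20 log units; within the scatter)) and sits far from the 2-methylprop-1-en-1-yl chain (a 47-fold higher number from compound 1 to compound 4 (1.67 log units; beyond the scatter)), so among these four compounds, both chains with a carbonyl give weaker inhibition than the two without one. Nothing available explains this difference.

Going by these compounds, it remains open whether the amide hydrogen, the isopropyl group or the chain length drives the reading of compound 4. A shorter amide chain, a tertiary amide, a carboxylic acid or an amine at the same place could help separate these features.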